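Adding one methoxy to compound 2

The source may hold more compounds than are shown below. What is called first, only, known or untested is meant among the compounds shown, and "the series" means these compounds.

Measured so far in a functional assay on MCF7 cells (Breast, Homo sapiens) (on this read-out lower numbers stand for an effect already at smaller amounts and higher numbers for an effect only at larger amounts of compound), across this series:

compound 1 `COc1cc2nc(-c3cccc(F)c3)nc(O)c2cc1OC` gives "not active" (no number reported)
compound 2 `COc1cccc(-c2nc(O)c3cc(OC)ccc3n2)c1` gives 37.5 ug/mL

Within the data shown here, compound 2 holds the only number in this small set, so it cannot be ranked, as the one other entry has no number. Next comes compound 3 (`COc1cccc(-c2nc(O)c3cc(OC)c(OC)cc3n2)c1`), which differs from compound 2 by methoxy in place of hydrogen on an aromatic carbon in the form of methoxy in place of hydrogen on an aromatic carbon, ortho to a methoxy group. Among the measured compounds shown here, no measured step exists to size this change. A small move toward higher numbers in this assay is expected, or none beyond the scatter. There is also some risk of no number at all, since compound 1, which also bears the added methoxy but differs elsewhere, gives "not active" (no number reported) in this read-out. Compound 3 is expected at 45 ug/mL with an estimated range from 15 ug/mL to 120 ug/mL for repeat measurements. The expected step is a 1.2-fold higher number from compound 2 to compound 3 (0.08 log units; within the scatter) overall.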

Compound 3, concentration for half-maximal effect: 14.5 ug/mL
Beside the measured number, compound 3's estimate is 3.1-fold (0.49 log units) above it; the measured number lies below the stated range.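

In this assay, methoxy in place of hydrogen on this aromatic carbon, ortho to a methoxy group, gives a 2.6-fold lower number from compound 2 to compound 3 (0.41 log units; beyond the scatter), the first measured size for this change in the series and one that points toward a lower number. Compound 3 has a number while compound 1, which carries the same added methoxy and has fluoro in place of a methoxy group elsewhere, gives "not active" (no number reported), so the added methoxy alone does not secure a measurable effect. Nothing available explains the size or direction of this step.

As far as these compounds go, whether the position also accepts an ethoxy group, an amine or a carboxylic acid remains open. Also open, from the compounds shown here alone, is whether the same methoxy step would appear with fluoro in that other place.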